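This account rests on a few compounds, and the source may have more. Where it says the series, first, only, none or still open, it means among the compounds named here.

Compound 1 `CCc1nnc(-c2ccc(-c3ccccc3)cc2)n1-c1cccc(Cl)c1C` and compound 2 `CCc1nnc(-c2ccc(-c3ccccc3)cc2)n1-c1cccc(Br)c1C` share one core and differ only in the halogen on the outer ring. In an assay on C6 glioma cells for displacement of a labelled ligand from sodium- and chloride-dependent glycine transporter 1 (Rattus norvegicus), read by scintillation counting, with stated times of 30 min and 10 min (on this read-out lower numbers stand for stronger inhibition and higher numbers for weaker inhibition), compound 1 gives 2200 nM, and in this assay compound 2 gives 2200 nM, so the move no change at the digits printed from compound 1 to compound 2 (within the scatter) left the read-out flat. Going by the values given here, compound 2 therefore stands level with compound 1, and nothing among the measured compounds sets it apart.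

Compound 3 `CCc1nnc(-c2ccc(-c3ccccc3)cc2)n1-c1cccc(C(=O)OC)c1C` carries the change (methoxycarbonyl in place of bromo on an aromatic carbon). Among the compounds with values here, no measured step exchanges a halogen for a methoxycarbonyl group, so the only guide is the flat halogen swap, which says little about a group of this kind. The step of a 1.8-fold higher number from compound 2 to compound 3 (0.26 log units; within the scatter) is therefore expected to be modest and is given a wide range. Compound 3 is estimated to give 4000 nM in this assay, with a range from 1000 nM to 20000 nM.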

Compound 3, half-maximal inhibitory concentration: 5100 nM
Beside the measured number, compound 3's estimate is 1.3-fold (0.11 log units) below it; the range from low to high includes it.
By their numbers in this assay, from the lowest: compounds 1 and 2 (each within the scatter of the next); then compound 3.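

In this assay methoxycarbonyl in place of bromo gives a 2.3-fold higher number from compound 2 to compound 3 (0.37 log units; beyond the scatter) and methoxycarbonyl in place of chloro gives a 2.3-fold higher number from compound 1 to compound 3 (0.37 log units; beyond the scatter) at the same aromatic carbon, ortho to a methyl group. Going by these compounds alone, the swap between the two halogens had left the read-out flat, so this is the first sign that the group on this carbon can move the number beyond the scatter, although only modestly and towards weaker inhibition. Nothing available here explains this rise.

Still open, as far as these compounds go, is whether any group on this carbon can bring the number below that of the two halogens. A carboxylic acid, an amide, an amine or a longer chain could each read differently, and one ester cannot show which way they would go.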